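Mixed aryl amine pair on the shared core

This account rests on a few compounds, and the source may have more. Where it says the series, first, only, none or still open, it means among the compounds named here.

Compound 1 `Cc1cccc(Nc2nc3nonc3nc2Nc2cccc(C)c2)c1` gives 2100 nM in an assay on mitochondria from L6 cells (Rattus norvegicus) for activation, with a stated time of 90 min; a lower number here means that less compound is needed, a higher number that more compound is needed for the effect; compound 2 `Fc1ccccc1Nc1nc2nonc2nc1Nc1cccc(F)c1F` gives 500 nM in this assay.

Of these two numbers, compound 2 holds the lower one, and its gap to compound 1 lies beyond the scatter. Compound 3 `Cc1cccc(Nc2nc3nonc3nc2Nc2ccccc2F)c1` has not yet been measured. It differs from compound 2 in one place: 3-methylphenyl in place of 2,3-difluorophenyl on a nitrogen on an aromatic ring. Going by the values given here, no measured step of this kind exists, so the size can only be estimated; a step in the direction of more compound needed, beyond the scatter, is expected a 2.2-fold higher number from compound 2 to compound 3 (0.34 log units; beyond the scatter). Compound 3 is estimated at 1100 nM, with a range from 400 nM to 2800 nM.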

Compound 3, half-maximal effective concentration: 1500 nM
Compound 3: the middle estimate sits 1.4-fold (0.13 log units) below what was measured; the measured number falls inside the stated range.
By their numbers in this assay, from the lowest: compound 2; then compounds 3 and 1 (each within the scatter of the next).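

Notes on the series: in this assay, 3-methylphenyl in place of 2,3-difluorophenyl on a nitrogen on an aromatic ring gives a 3.0-fold higher number from compound 2 to compound 3 (0.48 log units; beyond the scatter) as the first measured step at this place. With one 3-methylphenyl kept, 2-fluorophenyl in place of the other 3-methylphenyl gives a 1.4-fold lower number from compound 1 to compound 3 (0.15 log units; within the scatter), so that exchange does not separate the pair. No measured evidence bears on why either step has its size. Open, on these data alone, is how a methoxy group or an amine on this aromatic ring would read in this assay and whether either would match the number of compound 2.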